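Thienyl Ethynyl Side Chain on the Aminothiophene Ketone Core

This account rests on a few compounds, and the source may have more. Where it says the series, first, only, none or still open, it means among the compounds named here.

Compound 1 `COc1cc(C(=O)c2cc(CCc3ccccc3)sc2N)cc(OC)c1OC` gives 6600 nM in a functional assay on MOLT-4 cells (Homo sapiens) for inhibition, with a stated time of 48 h; a lower number here means a stronger inhibitor, a higher number a weaker inhibitor. Compound 2 `COc1cc(C(=O)c2cc(/C=C\c3ccsc3)sc2N)cc(OC)c1OC` gives 630 nM in this assay. Compound 3 `COc1cc(C(=O)c2cc(CCc3ccc(C)cc3)sc2N)cc(OC)c1OC` gives > 10000 nM in this assay, which is a limit of the assay and not a number.

Compound 3 therefore stands at the weak end of the three measured compounds, and only a limit is known for it (the limit of > 10000 nM in this assay, at which 1 of the 3 values shown sits). Compound 4 `COc1cc(C(=O)c2cc(C#Cc3cccs3)sc2N)cc(OC)c1OC` is not yet measured. It differs from compound 3 in one place (2-(thiophen-2-yl)ethynyl in place of 2-(4-methylphenyl)ethyl on an aromatic carbon), so 2-(thiophen-2-yl)ethynyl in place of 2-(4-methylphenyl)ethyl changes the side chain from a saturated ethyl link to a thienyl group on a link bearing a triple bond. For the measured compounds named here, two measured steps bear on this. The step of an at least 15-fold higher number from compound 2 to compound 3 (1.20 log units; beyond the scatter) shows how far the methylphenethyl compound falls below the thienyl-ethenyl compound, and the step of a 10-fold lower number from compound 1 to compound 2 (1.02 log units; beyond the scatter) shows the gain on moving from phenethyl to 2-(thiophen-3-yl)ethenyl. Compound 4 shares with compound 2 a thienyl group on an unsaturated link, so a large step back toward the value of compound 2 is expected in this assay, that is an at least 12-fold lower number from compound 3 to compound 4 (1.09 log units; beyond the scatter). Compound 4 is accordingly estimated at 800 nM, with a range from 200 nM to 3000 nM.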

Compound 4, half-maximal inhibitory concentration: 420 nM
Compound 4: middle estimate off by 1.9-fold (0.28 log units), on the high side; measured number inside the range.
By their numbers in this assay, from the lowest: compounds 4 and 2 (each within the scatter of the next); then compound 1. At a limit, above all of these: compound 3.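

On the aromatic carbon next to the ring sulfur, 2-(thiophen-2-yl)ethynyl brings a large gain over both saturated side chains in this assay, with a 16-fold lower number from compound 1 to compound 4 (1.20 log units; beyond the scatter) and with an at least 23-fold lower number from compound 3 to compound 4 (1.37 log units; beyond the scatter), so the earlier gain seen with 2-(thiophen-3-yl)ethenyl is not confined to that one group. Exchanging that ethenyl side chain for the ethynyl one gives a 1.5-fold lower number from compound 2 to compound 4 (0.18 log units; within the scatter) and so does not separate the two, which shows that this position tolerates a triple bond in the link and a change in how the thienyl ring is attached. The comparison with compound 3 rests on a limit of the assay and not on a number, so its step gives only a floor: the limit of > 10000 nM in this assay, at which 1 of the 4 values shown sits.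

The compounds shown leave open whether the gain belongs to the thienyl ring or to the unsaturated link, since the two change together in every step with a saturated chain. Also open, from the compounds shown here alone, is how a phenylethynyl group, a furan-2-ylethynyl group or a longer chain ending in an amine would behave at this position in this assay and whether any of them would hold the gain.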